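The compounds below may be only part of what the source reports. "The series", "measured", "known", "first", "only" and "open" are said of these compounds alone.

Compound 3 `C=C(Br)C(=O)Nc1ccc(/C=C2\SC(=O)N(Cc3ccc(C(F)(F)F)cc3)C2=O)cc1` is one of three compounds tested in a functional assay on FM3A cells (Mus musculus) for cytotoxicity, read by cell counting, with a stated time of 2 days (on this read-out lower numbers stand for stronger inhibition and higher numbers for weaker inhibition), where compound 3 gives 23000 nM. That number is the second highest of the three: compound 1 `Nc1ccc(/C=C2\SC(=O)N(Cc3ccc(Cl)cc3)C2=O)cc1` gives 60000 nM, and compound 2 `C=C(Br)C(=O)Nc1ccc(/C=C2\SC(=O)N(CC)C2=O)cc1` gives 2300 nM. Going by the values given here, the only measured step between neighbouring compounds is a 10-fold higher number from compound 2 to compound 3 (1.00 log units; beyond the scatter), a change on the saturated chain carbon bound to the amide-type nitrogen in the ring. Compound 4 `C=C(Br)C(=O)Nc1ccc(/C=C2\SC(=O)N(Cc3ccc(Cl)cc3)C2=O)cc1` differs from compound 3 instead on an aromatic carbon para to a large group: chloro in place of trifluoromethyl on an aromatic carbon. Among the compounds with values here, no measured step touches that aromatic carbon, so the data give no direction for compound 4 in this assay. The expected step is a 1.2-fold lower number from compound 3 to compound 4 (0.06 log units; within the scatter), within the scatter. The estimate for compound 4 is 20000 nM, ranging from 7000 nM to 60000 nM.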

Compound 4, half-maximal inhibitory concentration: 5100 nM
Compound 4: middle estimate off by 3.9-fold (0.59 log units), on the high side, and the stated range ends above it.
By their numbers in this assay, from the lowest: compound 2; then compound 4; then compound 3; then compound 1.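

In this assay the aromatic carbon para to a large group turns out to matter: chloro in place of trifluoromethyl gives a 4.5-fold lower number from compound 3 to compound 4 (0.65 log units; beyond the scatter) and so moves the number beyond the scatter. The 4-chlorophenyl in place of methyl still gives a 2.2-fold higher number from compound 2 to compound 4 (0.35 log units; beyond the scatter) in this series. Going by these compounds alone, the (1-bromoethenyl)carbonyl in place of hydrogen on the nitrogen gives a 12-fold lower number from compound 1 to compound 4 (1.07 log units; beyond the scatter) as the first reading of that group alone. Going by these compounds, whether a nitrile or a methoxy group on that aromatic carbon would lower the number further stays open. Nothing shown here accounts for these steps.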